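Aryloxyacetamide series: heteroaryl amide variant in HepG2 toxicity

This account rests on a few compounds, and the source may have more. Where it says the series, first, only, none or still open, it means among the compounds named here.

Working notes on the shared core of compound 1 `COc1ccc2nc(C)cc(OCC(=O)Nc3cc(C)cc(C)c3)c2c1`, which in a toxicity assay on HepG2 cells (Homo sapiens) for inhibition, read by CellTiter-Glo, with a stated time of 48 h (on this read-out higher numbers stand for weaker inhibition and lower numbers for stronger inhibition), gives 20000 nM. Compound 2 `COc1ccc2nc(C)cc(NC(=O)C(=O)Nc3cc(C)cc(C)c3)c2c1` carries an oxalamide linker instead of the oxyacetamide. In this assay compound 2 reaches only the limit of the assay, > 100000 nM, and no number. Compound 3 `COc1ccc2nc(C)cc(OCC(=O)Nc3cc(F)cc(F)c3)c2c1` keeps the oxyacetamide linker of compound 1. In this assay compound 3 also sits at the limit of the assay, > 100000 nM, which is not a number. Going by the values given here, the one measured step that reaches compound 3 is an at least 5.0-fold higher number from compound 1 to compound 3 (0.69 log units; beyond the scatter). Thus compound 3 stands at the weak end of what has been measured, with the limit of > 100000 nM in this assay, at which 2 of the 3 values shown sit, marking where most of the series sits.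

Compound 4 `COc1ccc2nc(C)cc(OCC(=O)Nc3ccncn3)c2c1` differs from compound 3 as follows: pyrimidin-4-yl in place of 3,5-difluorophenyl on an amide-type nitrogen. Among the compounds with values here, no measured step exchanges a carbon-only aromatic ring for a nitrogen-containing one on this nitrogen, so the step from compound 1 to compound 3 is the only guide, and it points toward weaker inhibition. The expectation for compound 4 is therefore no step beyond the scatter in this assay, with the limit likely reported again, expressed as a number no higher from compound 3 to compound 4 (the limit leaves the size open). Compound 4 is estimated at 100000 nM, with a range from 30000 nM to 300000 nM.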

Compound 4, half-maximal inhibitory concentration: > 100000 nM
Compound 4 gave a limit, no number; the forecaster's own chance of this, stated with the estimate: 75%; the middle value sits exactly at the limit.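

On the amide-type nitrogen, pyrimidin-4-yl in place of 3,5-dimethylphenyl gives an at least 5.0-fold higher number from compound 1 to compound 4 (0.69 log units; beyond the scatter) in this assay, so the shift toward weaker inhibition is no longer tied to a carbon-only aromatic ring bearing fluorine. The step between pyrimidin-4-yl and 3,5-difluorophenyl cannot be read, so no order can be stated between these two groups. Compound 4 joins compound 2 and compound 3 at one limit of the assay, which is not a number: the limit of > 100000 nM in this assay, at which 3 of the 4 values shown sit.

With most of the series at that limit, the data cannot separate the groups that reach it, and they give no cause for the shift away from the value of compound 1. On these data alone, how a pyridyl ring, with a single ring nitrogen, or a phenyl ring carrying a carboxylic acid would read on this amide-type nitrogen in this assay remains open, as does whether any such group would return a number rather than the limit.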